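This account rests on a few compounds, and the source may have more. Where it says the series, first, only, none or still open, it means among the compounds named here.

Compound 1 `O=[N+]([O-])c1ccc(NC(=S)NCCNS(=O)(=O)c2ccc(-c3ccccc3OCc3ccccc3)s2)cc1` and compound 3 `O=C(NCCNS(=O)(=O)c1ccc(-c2ccccc2OCc2ccccc2)s1)Nc1cc(Cl)cc(Cl)c1` share one core, while compound 2 `CC(C)c1ccc(Oc2ccc(O)c(O)c2)c(-c2ccsc2S(=O)(=O)NCCNC(=S)Nc2ccc([N+](=O)[O-])cc2)c1` and compound 4 `CC(C)c1ccc(Oc2ccc(O)c(O)c2)c(-c2ccsc2S(=O)(=O)NCCNC(=O)Nc2cc(Cl)cc(Cl)c2)c1` share another; the difference between the two cores is not broken down here. All were assessed in a functional assay on HL-60 cells (Homo sapiens) for inhibition, read by CCK-8 assay, with a stated time of 48 h; on this read-out higher numbers stand for weaker inhibition and lower numbers for stronger inhibition.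

In this assay compound 1 gives only a limit, > 50000 nM, rather than a number. In this assay compound 3 gives 11700 nM. In this assay compound 2 gives 8800 nM, a figure within the usual scatter of that of compound 3. Compound 2 and compound 3 therefore cannot be ranked against each other on this read-out.

The change from compound 1 to compound 3 is a group of 11 heavy atoms (7 carbon, 1 nitrogen, 1 oxygen, 2 chlorine; one six-membered aromatic ring of carbon only) in place of a group of 12 heavy atoms (7 carbon, 2 nitrogen, 2 oxygen, 1 sulfur; one six-membered aromatic ring of carbon only), on an amine nitrogen. It brought an at least 4.2-fold lower number from compound 1 to compound 3 (0.63 log units; beyond the scatter), and the step can only be given as a bound because of the limit of > 50000 nM in this assay, at which 1 of the 3 values shown sits. The change from compound 2 to compound 4 is a group of 11 heavy atoms (7 carbon, 1 nitrogen, 1 oxygen, 2 chlorine; one six-membered aromatic ring of carbon only) in place of a group of 12 heavy atoms (7 carbon, 2 nitrogen, 2 oxygen, 1 sulfur; one six-membered aromatic ring of carbon only), on an amine nitrogen, made at a place described in the same words as before, so it is the same change on a different core.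

From the compounds shown here alone, on that basis, the step from compound 2 to compound 4 in this assay is expected to be a 2.9-fold lower number from compound 2 to compound 4 (0.47 log units; beyond the scatter), somewhat smaller than the measured one, since the step from compound 1 to compound 3 rests on a limit and the true size of it is unknown. Compound 4 is thus estimated at 3000 nM in this assay, with a likely range from 1000 nM to 9000 nM.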

Compound 4, half-maximal inhibitory concentration: 6500 nM
Beside the measured number, compound 4's estimate is 2.2-fold (0.34 log units) below it; the range from low to high includes it.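

In this assay, putting (3,5-dichlorophenyl)carbamoyl in place of the leaving group on the amine nitrogen brought a 1.4-fold lower number from compound 2 to compound 4 (0.13 log units; within the scatter), so on this core the change has no effect that can be told from the scatter, and its size did not carry over from the other core: the same change on two cores in this assay, an at least 4.2-fold lower number (0.63 log units; beyond the scatter) from compound 1 to compound 3 and a 1.4-fold lower number (0.13 log units; within the scatter) from compound 2 to compound 4, at least 3.1-fold (0.49 log units) apart, beyond the scatter of two such steps

The gap between the two steps can be given only as a bound, and how much larger the step on the first core really is stays unknown, with compound 1 giving only a limit: the limit of > 50000 nM in this assay, at which 1 of the 4 values shown sits.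

The comparison rests on one pair on each core, so it shows that the size of this change depends on the core in these four compounds, but it does not show why, nor does it give a rule for the wider series.

The compounds shown leave open which part of the change matters, as the thiocarbonyl gives way to a carbonyl in the same step in which the nitro group on the aromatic ring gives way to two chlorines, so neither part can be read alone. They also leave open how either core would respond to an amine or a carboxylic acid on that aromatic ring, or to a longer chain on the amine nitrogen.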